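The source may hold more compounds than are shown below. What is called first, only, known or untested is meant among the compounds shown, and "the series" means these compounds.

Three compounds have been measured in a physicochemical assay for lipophilicity, read by LC-MS, in phosphate buffer, measured as octanol-water partition, with a stated time of 30 min, at pH 7.4, tested at 200 mM; a lower number here means a more polar compound, a higher number a more lipophilic compound:

- compound 1 `Cn1c(COc2cccc(C(=O)O)c2)nc2ccc(Oc3cccc(Cl)n3)cc21`: compound 1 gives 1.2
- compound 2 `Cn1c(COc2cccc(C(=O)O)c2)nc2ccc(Oc3ncccc3Cl)cc21`: compound 2 gives 1.1
- compound 3 `Cc1ccc(Oc2ccc3nc(COc4cccc(C(=O)O)c4)n(C)c3c2)nc1`: compound 3 gives 0.9

The three numbers lie within the scatter of one another. The step of a number 0.10 log units lower from compound 1 to compound 2 (within the scatter), the step of a number 0.30 log units lower from compound 1 to compound 3 (within the scatter) and the step of a number 0.20 log units lower from compound 2 to compound 3 (within the scatter) are all within the scatter, so compound 3 sits at one end of a narrow band and is not set apart from the other two.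

Compound 4 `Cc1cccnc1Oc1ccc2nc(COc3cccc(C(=O)O)c3)n(C)c2c1` differs from compound 3 in one place: 3-methylpyridin-2-yl in place of 5-methylpyridin-2-yl on an oxygen on an aromatic ring. Within the data shown here, the measured step that bears most directly on this change is the one from compound 1 to compound 2, where the chlorine on the pyridinyl ring moved while the ring itself stayed; that step was a number 0.10 log units lower from compound 1 to compound 2 (within the scatter), within the scatter. The steps into compound 3, which swapped a chloropyridinyl ring for a methylpyridinyl ring, were likewise within the scatter. Moving the methyl group on the pyridinyl ring is therefore expected to give no step beyond the scatter in this assay, that is, an expected no change at the digits printed from compound 3 to compound 4 (within the scatter). Compound 4 is accordingly estimated at 0.9, with a range from 0.5 to 1.3.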

Compound 4, distribution coefficient: 0.9
Compound 4: the middle estimate sits on the measured number at the digits printed; the range from low to high includes it.
By their numbers in this assay, from the lowest: compounds 3, 4, 2 and 1 (each within the scatter of the next).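

In this assay, among these compounds, the methyl group moved around the pyridinyl ring for the first time, and 3-methylpyridin-2-yl in place of 5-methylpyridin-2-yl on an oxygen on an aromatic ring gave no change at the digits printed from compound 3 to compound 4 (within the scatter), so a methyl shift joins the earlier chlorine shift as a change that stays within the scatter. Among the compounds shown here, compound 4 also gave the first direct exchange of methyl for chloro on an aromatic carbon, with the rest of the structure held fixed, which came to a number 0.20 log units lower from compound 2 to compound 4 (within the scatter), while the change from 6-chloropyridin-2-yl to 3-methylpyridin-2-yl gave a number 0.30 log units lower from compound 1 to compound 4 (within the scatter), so neither a shift of the group nor an exchange of methyl and chloro at this place has yet stepped beyond the scatter. No measurement is at hand that could explain these results.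

The compounds shown carry only methyl or chloro on the pyridinyl ring, so they leave open whether a ring bearing an amine, a methoxy group or a longer chain would stay within the same band in this assay. They also leave open how an unsubstituted phenyl ring would compare at this place, and whether a primary amide in place of the carboxylic acid would matter more than anything varied here.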